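This account rests on a few compounds, and the source may have more. Where it says the series, first, only, none or still open, it means among the compounds named here.

Compound 3 `CNC(=O)c1cccc(Cn2nc(C)c(NC(=O)c3ccc(COc4ccccc4C)cc3)c2C)c1` gives the lowest of the two numbers measured in a functional assay on MIA PaCa-2 cells (Homo sapiens) for antiproliferative activity, read by MTT assay, with a stated time of 72 h (a lower number here means that less compound is needed, a higher number that more compound is needed for the effect), namely 2100 nM. Compound 2 `Cc1nn(Cc2ccccc2C(N)=O)c(C)c1NC(=O)c1ccc(COc2ccccc2)cc1` gives 42000 nM in this assay. Compound 1 `Cc1nn(Cc2ccc(C(N)=O)cc2)c(C)c1NC(=O)c1ccc(COc2ccccc2)cc1` reaches only a limit of this assay, > 100000 nM, which is the limit of > 100000 nM in this assay, at which 1 of the 3 values shown sits. Within the data shown here, the single measured step, an at least 2.3-fold lower number from compound 1 to compound 2 (0.37 log units; beyond the scatter), moves the carbamoyl group on the benzyl side of the shared core and does not touch the part changed here. Compound 4 `CNC(=O)c1cccc(Cn2nc(C)c(NC(=O)c3ccc(COc4cccc(OC)c4)cc3)c2C)c1` differs from compound 3 by 3-methoxyphenyl in place of 2-methylphenyl on an oxygen on a saturated carbon. Among the measured compounds shown here, no measured step bears on this position, so no change beyond the scatter is expected; the estimated step is a 1.4-fold higher number from compound 3 to compound 4 (0.15 log units; within the scatter) in this assay. Compound 4 is expected to give about 3000 nM, between 1000 nM and 9000 nM.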

Compound 4, half-maximal effective concentration: 6200 nM
For compound 4 the middle estimate is 2.1-fold (0.32 log units) below the measured one, within the range that was stated.
By their numbers in this assay, from the lowest: compound 3; then compound 4; then compound 2. At a limit, above all of these: compound 1.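

In this assay, the group on this oxygen clearly affects the number: 3-methoxyphenyl in place of 2-methylphenyl gives a 3.0-fold higher number from compound 3 to compound 4 (0.47 log units; beyond the scatter). Among these compounds, the one earlier step concerned the carbamoyl group on the other side of the shared core, so this is the first measured change at this position. Nothing measured here explains the step. The change swaps both the substituent and its place on the ring, and the compounds shown do not separate these two. As far as these compounds go, a 2-methoxyphenyl or 3-methylphenyl group at this position would address that question, and how an aminophenyl group would behave also remains open.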